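The compounds below may be only part of what the source reports. "The series", "measured", "known", "first", "only" and "open" are said of these compounds alone.

Compounds in hand:
compound 1 `N=C(N)Nc1cccc(C(=O)NNC(=O)CC(CC(=O)O)c2ccc(F)cc2)c1` gives 1.28 in a physicochemical assay for lipophilicity; a lower number here means a more polar compound, a higher number a more lipophilic compound
compound 2 `N=C(N)Nc1cccc(C(=O)NNC(=O)CC(CC(=O)O)c2ccc(Cl)cc2)c1` gives 1.68
compound 3 `COc1ccc(C(CC(=O)O)CC(=O)NNC(=O)c2cccc(NC(=N)N)c2)cc1` gives 1

Compound 1 holds the second highest of the three numbers. Its nearest neighbour is compound 3, a number 0.28 log units lower from compound 1 to compound 3 (within the scatter), so the two cannot be ordered. Its furthest is compound 2, a number 0.40 log units higher from compound 1 to compound 2 (beyond the scatter).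

Compound 4 is `N=C(N)Nc1cccc(C(=O)NNC(=O)CC(CC(=O)O)c2ccc(-c3ccccc3)cc2)c1`. Relative to compound 1 the change is phenyl in place of fluoro on an aromatic carbon. The measured step that bears most directly on it is the one on the same aromatic carbon, a number 0.40 log units higher from compound 1 to compound 2 (beyond the scatter), where a heavier halogen replaced the fluoro; the step of a number 0.68 log units lower from compound 2 to compound 3 (beyond the scatter) shows the same position responding in the other direction. Going by the values given here, no measured step exchanges a halogen for a ring, so the size of this step has to be extrapolated from the single-substituent swaps. Phenyl brings in far more than chloro does, so the step is expected to be upward and clearly larger than the one from compound 1 to compound 2. The expected step for compound 4 is a number 1.52 log units higher from compound 1 to compound 4 (beyond the scatter). Compound 4 is therefore estimated at 2.8, with a range of 2.2 to 3.4.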

Compound 4, partition coefficient: 2.8
Compound 4: middle estimate and measured number agree at the digits printed; measured number inside the range.
By their numbers in this assay, from the lowest: compounds 3 and 1 (each within the scatter of the next); then compound 2; then compound 4.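

In this assay, phenyl on this aromatic carbon produces the largest steps in the series: a number 1.52 log units higher from compound 1 to compound 4 (beyond the scatter), a number 1.80 log units higher from compound 3 to compound 4 (beyond the scatter) and a number 1.12 log units higher from compound 2 to compound 4 (beyond the scatter). The earlier swaps among fluoro, chloro and methoxy covered a much narrower span, so these results show that this position can carry a whole aromatic ring and that compound 4 stands clear of all three earlier compounds. Nothing measured on these compounds accounts for the size of this rise.

The compounds shown leave open whether the rise follows the aromatic ring as such or simply the added carbon atoms, a question that a cyclohexyl group or a pyridyl ring on the same carbon would address. A hexyl chain there would show whether a ring is needed at all.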